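Adding Fluoro to Compound 3: An Expected Small Step

The compounds below may be only part of what the source reports. "The series", "measured", "known", "first", "only" and "open" are said of these compounds alone.

Compound 1 `Fc1ccccc1Nc1nc2nonc2nc1Nc1ccccc1` and compound 2 `Fc1ccc(Nc2nc3nonc3nc2Nc2ccccc2F)cc1` share a core and differ by fluoro in place of hydrogen on an aromatic carbon. In an assay on mitochondria from L6 cells (Rattus norvegicus) for activation, with a stated time of 90 min (on this read-out lower numbers stand for an effect already at smaller amounts and higher numbers for an effect only at larger amounts of compound), compound 1 gives 2200 nM, and compound 2 gives 2300 nM; the step is a 1.0-fold higher number from compound 1 to compound 2 (0.02 log units; within the scatter). Compound 3 `Fc1ccccc1Nc1nc2nonc2nc1Nc1cccc(C(F)(F)F)c1` differs from compound 1 by trifluoromethyl in place of hydrogen on an aromatic carbon. In this assay compound 3 gives only a limit, < 1000 nM, which marks an edge of what the assay reports and is not a number. The step is an at least 2.2-fold lower number from compound 1 to compound 3 (0.34 log units; beyond the scatter). Compound 4 `Fc1ccccc1Nc1nc2nonc2nc1Nc1cccc(C(F)(F)F)c1F` is not yet measured; it differs from compound 3 by fluoro in place of hydrogen on an aromatic carbon. This is the same kind of change as from compound 1 to compound 2, but not the same: there the fluoro sits para to a large group, here it sits ortho to a large group and ortho to a trifluoromethyl group. Because the earlier step of a 1.0-fold higher number from compound 1 to compound 2 (0.02 log units; within the scatter) stayed within the scatter, only a small step is expected, a step that the limit leaves unreadable from compound 3 to compound 4. Since compound 3 sits at the limit of < 1000 nM in this assay, at which 1 of the 3 values shown sits, only a limit could again be reported. Compound 4 is expected to give about 700 nM, between 250 nM and 2000 nM.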

Compound 4, half-maximal effective concentration: < 370 nM
Compound 4 was reported as a limit; the forecaster's own chance of this, stated with the estimate: 40%; middle value at least 1.8-fold (0.27 log units) away from the limit.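

Within the data shown here, compound 3 and compound 4 are both reported only as limits in this assay, and no step from compound 3 to compound 4 can be read from two limits. The compounds shown leave open whether fluoro in place of hydrogen on this aromatic carbon changes the read-out at all, and by how much.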